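The source may report more compounds than this note shows. Statements on the series, on what has been measured and on what is new or still open speak of the compounds shown alone.

Measured compounds in a functional assay on LNCaP cells (Homo sapiens) for antiproliferative activity, read by fluorescence and propidium iodide staining, with a stated time of 96 h; on this read-out higher numbers stand for weaker inhibition and lower numbers for stronger inhibition:
- compound 1 `O=C(Nc1ccc(S(F)(F)(F)(F)F)cc1)c1ccc(Sc2ccc(O)cc2)cc1`: 4860 nM
- compound 2 `O=C(Nc1ccccc1C(F)(F)F)c1ccc(Sc2ccc(O)cc2)cc1`: 11400 nM
- compound 3 `O=C(Nc1ccc(S(F)(F)(F)(F)F)cc1)c1ccc([S+]([O-])c2ccc(O)cc2)cc1`: 900 nM

Compound 1 and compound 2 share the (4-hydroxyphenyl)sulfanyl arm but carry different anilide cores; how the two cores differ is not broken down here. In this assay compound 2 gives 11400 nM, the highest of the three numbers, while compound 1 gives 4860 nM and compound 3 gives 900 nM.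

Compound 3 is obtained from compound 1 by a single change, (a group of 9 heavy atoms (6 carbon, 2 oxygen, 1 sulfur; one six-membered aromatic ring of carbon only) in place of a group of 8 heavy atoms (6 carbon, 1 oxygen, 1 sulfur; one six-membered aromatic ring of carbon only), on an aromatic carbon), and that change brought a 5.4-fold lower number from compound 1 to compound 3 (0.73 log units; beyond the scatter).

Compound 4 `O=C(Nc1ccccc1C(F)(F)F)c1ccc([S+]([O-])c2ccc(O)cc2)cc1` is still unmeasured. It stands to compound 2 as compound 3 stands to compound 1, the change being (a group of 9 heavy atoms (6 carbon, 2 oxygen, 1 sulfur; one six-membered aromatic ring of carbon only) in place of a group of 8 heavy atoms (6 carbon, 1 oxygen, 1 sulfur; one six-membered aromatic ring of carbon only), on an aromatic carbon), made at the same place and therefore the same change. Because compound 1 to compound 3 gave a 5.4-fold lower number from compound 1 to compound 3 (0.73 log units; beyond the scatter), the step from compound 2 to compound 4 is expected to be of a similar size, estimated as a 4.6-fold lower number from compound 2 to compound 4 (0.66 log units; beyond the scatter), though it rests on a single prior instance. Compound 4 is accordingly expected to give about 2500 nM in this assay, with a plausible span from 1000 nM to 6500 nM.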

Compound 4, half-maximal inhibitory concentration: 62000 nM
Beside the measured number, compound 4's estimate is 25-fold (1.39 log units) below it; measured number above the stated range.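

On the core of compound 2, the change brought a 5.4-fold higher number from compound 2 to compound 4 (0.74 log units; beyond the scatter) in this assay. The result of this change therefore depends on the core that carries it, and the steps on the two cores run in opposite directions: the same change on two cores in this assay, a 5.4-fold lower number (0.73 log units; beyond the scatter) from compound 1 to compound 3 and a 5.4-fold higher number (0.74 log units; beyond the scatter) from compound 2 to compound 4, 29-fold (1.47 log units) apart, beyond the scatter of two such steps

Within the data shown here, this shows that the gain seen on the core of compound 1 cannot be assumed to carry over to the core of compound 2, but with only two cores it gives no general rule, and it does not show which difference between the cores reverses the step.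

The compounds shown leave open how the same change behaves on an anilide core bearing another group, such as a nitrile or a chlorine atom, and which core feature decides its direction. They also leave open what a sulfonyl linker, or a methoxy group or an amine in place of the hydroxyl, would do on either core.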